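Two Enantiomers of a Thiourea Piperazine: Cytotoxicity Compared

This account rests on a few compounds, and the source may have more. Where it says the series, first, only, none or still open, it means among the compounds named here.

Measured compounds:
compound 1, `CC1CN(C(=O)CC(C)(C)C)CCN1C(=S)Nc1cc(C(F)(F)F)cc(C(F)(F)F)c1`, 73200 nM
compound 2, `O=C(CC1CCCCC1)N1CCN(C(=S)Nc2cc(C(F)(F)F)cc(C(F)(F)F)c2)C(c2ccccc2)C1`, 125000 nM
compound 3, `C[C@@H]1CN(C(=O)CC(C)(C)C)CCN1C(=S)Nc1cc(C(F)(F)F)cc(C(F)(F)F)c1`, 162000 nM

In an ADME assay on A549 cells (Homo sapiens) for cytotoxicity (on this read-out higher numbers stand for lower toxicity in this test and lower numbers for higher toxicity in this test), compound 3 holds the highest of the three numbers, compound 2 lying within the scatter of it and compound 1 further off. Among the compounds with values here, the only step measured between compounds that differ in a single place is a 2.2-fold higher number from compound 1 to compound 3 (0.35 log units; beyond the scatter), and the difference at that place is the fact that one of compounds 1 and 3 is drawn with a defined configuration and the other without, at the place where they differ.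

Compound 4, `C[C@H]1CN(C(=O)CC(C)(C)C)CCN1C(=S)Nc1cc(C(F)(F)F)cc(C(F)(F)F)c1`, differs from compound 3 in that (the two compounds have the same atoms and bonds and differ only in configuration as drawn: 1 of 1 stereo elements differ; a stereocentre at a saturated ring carbon is drawn R in compound 3 and S in compound 4). The step from compound 1 to compound 3 bears on this change: if the drawing without configuration stands for a mixture of both forms, the S form would account for the lower number of compound 1. Compound 4 is therefore expected to show a modest downward step, a 3.2-fold lower number from compound 3 to compound 4 (0.51 log units; beyond the scatter). Compound 4 is estimated at 50000 nM, within a range of 25000 nM to 120000 nM.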

Compound 4, half-maximal cytotoxic concentration: 73500 nM
Compound 4: middle estimate off by 1.5-fold (0.17 log units), on the low side; measured number inside the range.
By their numbers in this assay, from the lowest: compounds 1, 4, 2 and 3 (each within the scatter of the next, the first and the last beyond it).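

In this assay, configuration at the saturated ring carbon is now seen to matter on its own, with a 2.2-fold lower number from compound 3 to compound 4 (0.34 log units; beyond the scatter), the R form standing apart from the S form: the fact that compounds 3 and 4 differ only in the configuration as drawn. Compound 1, drawn without a configuration, does not fall between the two forms, with a 1.0-fold higher number from compound 1 to compound 4 (0.00 log units; within the scatter), and so cannot be told apart from the S form here: the fact that one of compounds 1 and 4 is drawn with a defined configuration and the other without, at the place where they differ. On these data alone, whether the same gap between the R and S forms holds with an ethyl group or an amine in place of the methyl at this carbon remains open. So does whether it persists with a longer chain on the amide.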